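A few compounds are considered here, and "the series" means these few. Any claim that something is new, unique, unknown or untested is made for them only; others in the source may bear on it.

Measured compounds and their values in a functional assay on HCT-116 cells (Homo sapiens) for antiproliferative activity, read by MTT assay; a higher number here means a weaker inhibitor, a lower number a stronger inhibitor:

Compound 1 `COc1cccc(/C=N/Nc2ncc3c(n2)n(C2CCCC2)c(=O)c(=O)n3C)c1`: 45800 nM
Compound 2 `Cn1c(=O)c(=O)n(C2CCCC2)c2nc(N/N=C/c3ccco3)ncc21`: 78700 nM
Compound 3 `Cn1c(=O)c(=O)n(C2CCCC2)c2nc(N/N=C/c3ccc(F)cc3Cl)ncc21`: 13800 nM

Compound 1 stands second highest of the three numbers in this assay. Its nearest neighbour is compound 2, where the step is a 1.7-fold higher number from compound 1 to compound 2 (0.24 log units; within the scatter), so the two cannot be told apart. The furthest is compound 3, where the step is a 3.3-fold lower number from compound 1 to compound 3 (0.52 log units; beyond the scatter), a modest gain. Between the other two the step is a 5.7-fold lower number from compound 2 to compound 3 (0.76 log units; beyond the scatter), also modest and in the same direction.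

Compound 4 `Cn1c(=O)c(=O)n(C2CCCC2)c2nc(N/N=C/c3ccc(F)cc3F)ncc21` differs from compound 1 as follows: 2,4-difluorophenyl in place of 3-methoxyphenyl on a carbon with a double bond to nitrogen. For the measured compounds named here, the step that bears on this most directly is the one to compound 3, since there too a halogenated phenyl replaced the 3-methoxyphenyl on the carbon with a double bond to nitrogen and gave a 3.3-fold lower number from compound 1 to compound 3 (0.52 log units; beyond the scatter). The 2,4-difluorophenyl is not the 2-chloro-4-fluorophenyl, so the size of that gain is only a guide, not a rule; the two other measured steps concern the furan-2-yl and say little here.

For compound 4 a modest improvement in this assay is therefore expected, with the estimated step being a 2.3-fold lower number from compound 1 to compound 4 (0.36 log units; beyond the scatter). The estimate for compound 4 is 20000 nM, with a range from 8000 nM to 50000 nM.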

Compound 4, half-maximal inhibitory concentration: 19800 nM
Estimate against measurement, compound 4: 1.0-fold (0.00 log units) above; low and high end bracket the measured number.
By their numbers in this assay, from the lowest: compounds 3 and 4 (each within the scatter of the next); then compounds 1 and 2 (each within the scatter of the next).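

In this assay, the 2,4-difluorophenyl on the carbon with a double bond to nitrogen improves on the 3-methoxyphenyl, with a 2.3-fold lower number from compound 1 to compound 4 (0.36 log units; beyond the scatter), and on the furan-2-yl, with a 4.0-fold lower number from compound 2 to compound 4 (0.60 log units; beyond the scatter), so the gain seen with the 2-chloro-4-fluorophenyl is not unique to that group and now extends to a second halogenated phenyl. The new pair also isolates a single atom on the ring: fluoro in place of chloro on an aromatic carbon gives a 1.4-fold higher number from compound 3 to compound 4 (0.16 log units; within the scatter), so among these compounds that chloro is not needed for the gain, and compound 3 and compound 4 cannot be told apart. No measurement offered here accounts for any of these differences.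

The compounds shown leave open whether both halogens are needed, which a phenyl carrying only a single fluoro or an unsubstituted phenyl at this place would help to settle. They also leave open how this position would respond to a phenyl bearing an amine or a carboxylic acid, since only the 3-methoxyphenyl, the furan-2-yl and the two halogenated phenyls appear here.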